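The source may hold more compounds than are shown below. What is called first, only, known or untested is meant among the compounds shown, and "the series" means these compounds.

The series shares a piperidine-linked aniline core that carries a cyclic ketone, and the variation sits on the ring amine. Compound 1 `CCc1cnc(N2CCC(CCCNc3ccc4c(c3)C(=O)CC4)CC2)nc1` bears a pyrimidine on that nitrogen, and in a functional assay on CHO-K1 cells for agonist activity at Glucose-dependent insulinotropic receptor (Mus musculus), read by HTRF and cAMP accumulation, with a stated time of 30 min (on this read-out higher numbers stand for larger maximal responses and lower numbers for smaller maximal responses), compound 1 gives 110%. Compound 2 `CC(C)(C)OC(=O)N1CCC(CCCNc2ccc3c(c2)OCC3=O)CC1` carries a tert-butyl carbamate at the same place, and in this assay compound 2 gives 108%. The two values lie within the usual scatter of each other, so neither can be called the larger response.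

Compound 3 `CC(C)c1noc(N2CCC(CCCNc3ccc4c(c3)OCC4=O)CC2)n1` carries a 3-isopropyl-1,2,4-oxadiazol-5-yl on the amine nitrogen in the ring; in this assay compound 3 gives "not determined" (no result reported), so it stands without a number on the values shown. Compound 4 `CC(C)c1nsc(N2CCC(CCCNc3ccc4c(c3)OCC4=O)CC2)n1` differs from compound 3 by a single exchange: 3-isopropyl-1,2,4-thiadiazol-5-yl in place of 3-isopropyl-1,2,4-oxadiazol-5-yl on an amine nitrogen in a ring. For the measured compounds named here, no step between measured compounds exists for this pair, and the change keeps every count the same apart from the sulfur that replaces the oxygen.

Both measured neighbours reach a full maximal response, and no step beyond the scatter has been shown anywhere in the set, so no shift beyond the scatter is expected for compound 4 in this assay. Compound 4 is therefore estimated at 105% in this assay, with a range from 85% to 125%.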

Compound 4, largest response reached (Emax), in percent of the reference or control that the assay uses: 93%
Compound 4: the middle estimate sits 12 percentage points above what was measured, within the range that was stated.
By their numbers in this assay, from the lowest: compound 4; then compounds 2 and 1 (each within the scatter of the next).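

In this assay, for the compounds shown here, putting 3-isopropyl-1,2,4-thiadiazol-5-yl in place of tert-butoxycarbonyl on the amine nitrogen in a ring gives a number 15 percentage points lower from compound 2 to compound 4 (beyond the scatter) and so provides the first step in the set that lies beyond the scatter. Going by these compounds alone, this shows that the maximal response is not indifferent to the group at this position, which the earlier compounds could not show, although the step is modest and compound 4 still reaches 93% in this read-out. No measurement shown here accounts for the lower response of the thiadiazole compound.

Going by these compounds, the exchange of 3-isopropyl-1,2,4-oxadiazol-5-yl for 3-isopropyl-1,2,4-thiadiazol-5-yl cannot be read, since compound 3 has no number, and so it remains open whether the sulfur itself matters or whether the oxadiazole would sit closer to the carbamate. On these data alone, it also remains open how far the response would move with a simple acetyl group, a plain isopropyl group or a carboxylic acid on this ring nitrogen, and whether the step seen here would hold for such groups.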